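Methoxy for bromo at a second site in the enone-nitrile series

The compounds below may be only part of what the source reports. "The series", "measured", "known", "first", "only" and "open" are said of these compounds alone.

Measured compounds:
compound 1 `COc1ccc(/C(Cl)=C/C=C(\C#N)C(=O)c2c(C)[nH]c3ccccc23)cc1`: 34.2%
compound 2 `COc1cc(/C(Cl)=C/C=C(\C#N)C(=O)c2c[nH]c3ccc(Br)cc23)cc(OC)c1OC`: 26.3%
compound 3 `Cc1[nH]c2ccccc2c1C(=O)/C(C#N)=C/C=C(\Cl)c1ccc(Br)cc1`: 15.8%

Three compounds have been run in a functional assay for inhibition, with a stated time of 30 min, tested at 1 mM; on this read-out higher numbers stand for more inhibition at the one concentration tested (going by the name of the read-out) and lower numbers for less inhibition. Compound 1 gives 34.2% in this assay, compound 2 gives 26.3% and compound 3 gives 15.8%. Compound 1 and compound 3 differ in one place, (methoxy in place of bromo on an aromatic carbon), and this change gives a number 18.4 percentage points higher from compound 3 to compound 1 (beyond the scatter). Compound 2 stands second highest of the three; its value and that of compound 1 lie within the scatter of each other, while the gap to compound 3 lies beyond it. The difference between the cores of compound 2 and compound 3 is not broken down here.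

Compound 4 `COc1ccc2[nH]cc(C(=O)/C(C#N)=C/C=C(\Cl)c3cc(OC)c(OC)c(OC)c3)c2c1` has not yet been measured. It differs from compound 2 by methoxy in place of bromo on an aromatic carbon. For the measured compounds named here, this is the same kind of change as the one between compound 3 and compound 1, but not the same: in compound 1 the methoxy sits on a six-membered aromatic ring of carbon only, para to a large group, whereas in compound 4 it sits on a six-membered aromatic ring of carbon only that is part of a fused or bridged system of two rings, meta to a fused ring and para to a fused ring. Going by the values given here, only one earlier instance exists, on the other ring, so the step here is uncertain. Because a number 18.4 percentage points higher from compound 3 to compound 1 (beyond the scatter) was modest and upward, a smaller step is expected for compound 4, namely a number 5.7 percentage points higher from compound 2 to compound 4 (within the scatter), likely within the scatter. Compound 4 is thus estimated at 32% in this assay, with a range from 18% to 46%.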

Compound 4, a percentage reported as inhibition, at one concentration (the size of the read-out at that concentration, not a potency): 46.1%
The estimate for compound 4 lay 14.1 percentage points below the measured number; the whole stated range lies below it.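

In this assay, methoxy in place of bromo on an aromatic carbon gives a number 19.8 percentage points higher from compound 2 to compound 4 (beyond the scatter), and the step is of matching size on the two cores: the same change on two cores in this assay, a number 18.4 percentage points higher (beyond the scatter) from compound 3 to compound 1 and a number 19.8 percentage points higher (beyond the scatter) from compound 2 to compound 4, 1.4 percentage points apart, within the scatter of two such steps

Within these two pairs, the change carries from one core to the other with its size intact, even though the site differs: in compound 4 the methoxy stands on a six-membered aromatic ring of carbon only, part of a fused or bridged system of two rings, while in compound 1 it stands on the other ring. Two pairs do not make a rule for the series, and they give no explanation for the step, nor do they show how it would look as a potency, since each number is a read-out at a single concentration.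

As far as these compounds go, it remains open whether the same step appears on cores beyond these two, and whether methoxy at both sites in one molecule would add up. From the compounds shown here alone, it also remains open how an amine, a carboxylic acid or a longer alkoxy chain would compare with methoxy and bromo at either site.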